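Ethoxy for Phenyl on a Dichlorinated Core

The source may report more compounds than this note shows. Statements on the series, on what has been measured and on what is new or still open speak of the compounds shown alone.

Measured compounds:
compound 1 `O=c1c([C@@H]2C[C@H](c3ccccc3)ON2c2ccccc2)coc2cc(Cl)c(Cl)cc12`: 32000 nM
compound 2 `CCO[C@H]1C[C@@H](c2coc3ccc(F)cc3c2=O)N(c2ccccc2)O1`: 31700 nM
compound 3 `O=C1[C@H]2[C@H](ON(c3ccccc3)[C@@H]2c2coc3ccc(F)cc3c2=O)C(=O)N1c1ccccc1`: > 60000 nM

All three were run in a functional assay on PC-3 cells (Homo sapiens) for inhibition, read by sulforhodamine B assay, with a stated time of 48 h; on this read-out lower numbers stand for stronger inhibition and higher numbers for weaker inhibition. Compound 1 gives 32000 nM, the higher of the two numbers, yet compound 2 at 31700 nM stands at a gap within the scatter. Compound 3 reached (the limit of > 60000 nM in this assay, at which 1 of the 3 values shown sits), a limit and not a number. Compound 4 `CCO[C@H]1C[C@@H](c2coc3cc(Cl)c(Cl)cc3c2=O)N(c2ccccc2)O1` is not yet measured. From compound 1 to compound 4, ethoxy in place of phenyl on a saturated ring carbon. Among the measured compounds shown here, no measured pair differs in one place, so the step of no change at the digits printed from compound 1 to compound 4 (within the scatter) is expected to stay within the scatter, in no particular direction. Because compound 2 shows 31700 nM with the same ethoxy, compound 4 is estimated at 32000 nM, between 12000 nM and 80000 nM.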

Compound 4, half-maximal inhibitory concentration: > 60000 nM
Compound 4: a limit, no number (the forecaster's own chance of this, stated with the estimate: 25%); at least 1.8-fold (0.27 log units) between middle value and limit.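

On the core of compound 1, ethoxy in place of phenyl on a saturated ring carbon gives an at least 1.8-fold higher number from compound 1 to compound 4 (0.27 log units; that floor lies within the scatter) in this assay. This is the first step shown that changes one place only, but the value of compound 4 is a limit and not a number, so only a floor for the step can be read. The change at this position takes the read-out out of measurable range: the limit of > 60000 nM in this assay, at which 2 of the 4 values shown sit.

On these data alone, how far compound 4 truly lies from compound 1 stays open. So does what an amine or a longer chain on this ring carbon would give.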